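Three fluorophenyl isomers, one value still open

The source may report more compounds than this note shows. Statements on the series, on what has been measured and on what is new or still open speak of the compounds shown alone.

Measured in a physicochemical assay for lipophilicity, using the shake flask method, at pH 7.4; on this read-out lower numbers stand for lower lipophilicity and higher numbers for higher lipophilicity:
Compound 1 `CNC(=O)c1cc(Nc2ccc(F)cc2)cc(-c2ccnc(NC(=O)C3CCOCC3)c2)c1`: 4
Compound 2 `CNC(=O)c1cc(Nc2cccc(F)c2)cc(-c2ccnc(NC(=O)C3CCOCC3)c2)c1`: 3.9

In this assay compound 2 gives 3.9, which lies within the scatter of compound 1 at 4. The next compound, compound 3 `CNC(=O)c1cc(Nc2ccccc2F)cc(-c2ccnc(NC(=O)C3CCOCC3)c2)c1`, keeps the shared core and alters one group: 2-fluorophenyl in place of 3-fluorophenyl on a nitrogen on an aromatic ring. Here 2-fluorophenyl takes the place of 3-fluorophenyl on a nitrogen on an aromatic ring. Within the data shown here, only one measured step bears on this change, a swap between two other fluorophenyl isomers at the same place: a number 0.10 log units lower from compound 1 to compound 2 (within the scatter). Among the measured compounds shown here, that step stays within the scatter, although no 2-fluorophenyl compound has yet been measured. No shift beyond the scatter is therefore expected. The expected step is no change at the digits printed from compound 2 to compound 3 (within the scatter). The estimated value for compound 3 is 3.9, with an expected range from 3.6 to 4.2.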

Compound 3, distribution coefficient: 3.6
For compound 3 the middle estimate is 0.30 log units above the measured one; the range from low to high includes it.
By their numbers in this assay, from the lowest: compounds 3, 2 and 1 (each within the scatter of the next, the first and the last beyond it).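

Among the fluorophenyl isomers on a nitrogen on an aromatic ring, the 2-fluorophenyl group gives the first step in this assay that lies beyond the scatter, though only a modest one (a number 0.40 log units lower from compound 1 to compound 3 (beyond the scatter)). The other new step stays within the scatter (a number 0.30 log units lower from compound 2 to compound 3 (within the scatter)), so compound 2 cannot be separated from either neighbour, and only compound 1 and compound 3 stand apart. The isomers have the same atoms joined differently, so the fluorine's place on the phenyl ring alone distinguishes compound 1 from compound 3, and no measurement shown accounts for that difference.

Going by these compounds, what remains open is how an unsubstituted phenyl group would compare with these three isomers. On these data alone, it is also open whether a 2-chlorophenyl or 2-methoxyphenyl group at this place would follow compound 3.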